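Lengthening the chain substituent from ethyl to propyl

The source may hold more compounds than are shown below. What is called first, only, known or untested is meant among the compounds shown, and "the series" means these compounds.

The compounds measured so far:
Compound 1 `Cc1ccc2c(c1)C(C(C)c1ccccn1)=C(CCN(C)C)C2`: 5890 nM
Compound 2 `CCC(C1=C(CCN(C)C)Cc2cc(Cl)ccc21)c1ccccn1`: 776 nM
Compound 3 `CCC(C1=C(CCN(C)C)Cc2ccccc21)c1ccccn1`: 676 nM

In an assay on CHO-K1 cells for binding affinity to muscarinic acetylcholine receptor M5 (Homo sapiens) (on this read-out lower numbers stand for stronger inhibition and higher numbers for weaker inhibition), compound 3 gives the lowest of the three numbers. Compound 2 stands closest to it: a 1.1-fold lower number from compound 2 to compound 3 (0.06 log units; within the scatter), so these two cannot be told apart. Compound 1, which differs from compound 3 in two places at once, a methyl on the shared core and a methyl rather than an ethyl on the chain carbon, gives a number that is well beyond the scatter from compound 3; since two changes are combined, no single one of them can be credited with the gap.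

Compound 4 `CCCC(C1=C(CCN(C)C)Cc2ccccc21)c1ccccn1` is the next step from compound 3: methyl in place of hydrogen on a saturated chain carbon, three bonds along the chain from an aromatic carbon and a double-bonded ring carbon. Among the compounds with values here, no measured step touches exactly this position; the only pair that varies the group on this chain carbon is compound 1 against compound 3, and that comparison is confounded by the second change on the core. Within the data shown here, the one clean step, from compound 2 to compound 3, concerns a different place and was within the scatter.

With that thin basis, compound 4 is expected to stay close to compound 3, with an estimated step of a 1.4-fold lower number from compound 3 to compound 4 (0.13 log units; within the scatter), a small shift at most. Compound 4 is therefore estimated at 500 nM in this assay, with a range from 200 nM to 1500 nM.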

Compound 4, inhibition constant: 302 nM
Compound 4: middle estimate off by 1.7-fold (0.22 log units), on the high side, and the stated range covers the measured number.
By their numbers in this assay, from the lowest: compound 4; then compounds 3 and 2 (each within the scatter of the next); then compound 1.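

In this assay, within the data shown here, the change from ethyl to propyl on this chain carbon is the first clean reading at this position: a 2.2-fold lower number from compound 3 to compound 4 (0.35 log units; beyond the scatter), a modest step, but one that lies beyond the scatter. The earlier compounds could not show this, since the comparison of compound 1 with compound 3 also carried a change on the shared core, and the one clean step, a 1.1-fold lower number from compound 2 to compound 3 (0.06 log units; within the scatter), concerned a different place and showed no measurable shift, so a single added methyl here is the first one-place change shown to move the number beyond the scatter. Nothing available explains why this added methyl lowers the number.

The compounds shown leave open whether the number keeps falling with a still longer chain such as butyl, or whether a branched isopropyl or a cyclopropyl ring on the same carbon would do as well as propyl. They also leave open whether propyl gives a similar step on a core carrying the chloro of compound 2 or the methyl of compound 1.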